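The source may hold more compounds than are shown below. What is called first, only, known or untested is meant among the compounds shown, and "the series" means these compounds.

Of the compounds shown here, three have so far been measured in a functional assay (aorta) with Oryctolagus cuniculus as the target; a higher number here means a weaker inhibitor, a lower number a stronger inhibitor. Compound 1 `OCc1ccc(-c2nn(Cc3ccccc3F)c3ccccc23)o1` gives 4900 nM; 4900 nM (2 entries) there, and compound 2 `OCc1ccc(-c2nn(Cc3ccccc3F)c3cccnc23)o1` gives 20400 nM. Compound 3 `CCc1cnc(-c2nn(Cc3ccccc3F)c3ncccc23)nc1N` gives 272000 nM, the highest of the two single numbers, and its gap from compound 2 lies well beyond the usual scatter. Compound 4 `CCCCc1cnc(-c2nn(Cc3ccccc3F)c3ncccc23)nc1N` differs from compound 3 in one place only: ethyl in place of hydrogen on a saturated chain carbon, two bonds along the chain from an aromatic carbon. For the measured compounds named here, no measured pair shows this kind of change, so its effect cannot be read from these data. Such a lengthening of the chain is expected to shift the number in this assay only modestly, in either direction or not beyond the scatter. For compound 4 the expected value in this assay is 150000 nM, within a range from 40000 nM to 500000 nM. That corresponds to an expected step of a 1.8-fold lower number from compound 3 to compound 4 (0.26 log units; within the scatter).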

Compound 4, half-maximal inhibitory concentration: 218000 nM
The estimate for compound 4 lay 1.5-fold (0.16 log units) below the measured number, and the stated range covers the measured number.
By their numbers in this assay, from the lowest: compound 2; then compounds 4 and 3 (each within the scatter of the next).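

In this assay the change of ethyl to butyl gives a 1.2-fold lower number from compound 3 to compound 4 (0.10 log units; within the scatter) and so produces no readable shift. For this one pair, ethyl can therefore replace hydrogen on this saturated chain carbon without moving the number beyond the scatter. No measurement shown offers any explanation for this result. Going by these compounds, whether a longer chain, an amine or a carboxylic acid on this carbon would move the number beyond the scatter stays open. On these data alone, whether the same change would behave alike on a different core also stays open.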